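Pyrazole carbamates: ring methyl removal across two core types

A few compounds are considered here, and "the series" means these few. Any claim that something is new, unique, unknown or untested is made for them only; others in the source may bear on it.

Working notes on a small set tested in an assay on membranes from brain for binding affinity to Monoacylglycerol lipase ABHD6 (Mus musculus), read by fluorescence, with stated times of 1 h and 30 min; on this read-out lower numbers stand for stronger inhibition and higher numbers for weaker inhibition. Compound 1 `Cc1cnn(C(=O)N2CCCN(Cc3ccc(OCc4ccccc4)cc3)CC2)c1` gives 9500 nM. Built on the same core, compound 2 `O=C(N1CCCN(Cc2ccc(OCc3ccccc3)cc2)CC1)n1cccn1` gives 960 nM. The step of a 9.9-fold lower number from compound 1 to compound 2 (1.00 log units; beyond the scatter) is hydrogen in place of methyl on an aromatic carbon. Compound 3 `Cc1cnn(C(=O)N(C)CCN(C)Cc2ccc(OCc3ccccc3)cc2)c1`, built on a different core, gives 1200 nM; the difference between the core of compound 3 and the core of compound 1 is not broken down here, and the two values of compound 3 and compound 2 sit within the scatter of each other.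

Compound 4 `CN(CCN(C)C(=O)n1cccn1)Cc1ccc(OCc2ccccc2)cc1` has not been measured in this assay. It differs from compound 3 by hydrogen in place of methyl on an aromatic carbon, the same change as between compound 1 and compound 2, at the same kind of place in the five-membered aromatic ring. Within the data shown here, for compound 4 the step of a 6.0-fold lower number from compound 3 to compound 4 (0.78 log units; beyond the scatter) is expected, resting on the step of a 9.9-fold lower number from compound 1 to compound 2 (1.00 log units; beyond the scatter) as the only measured instance of this change, tempered because compound 3 at 1200 nM already sits lower than compound 1. Compound 4 is estimated at 200 nM, with a range from 60 nM to 650 nM.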

Compound 4, half-maximal inhibitory concentration: 530 nM
Compound 4: the middle estimate sits 2.7-fold (0.42 log units) below what was measured, and the stated range covers the measured number.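

In this assay, the change from 4-methyl-1H-pyrazol-1-yl to 1H-pyrazol-1-yl on the second core gives a 2.3-fold lower number from compound 3 to compound 4 (0.35 log units; beyond the scatter), so the direction of the step on the first core carries over. Its size does not carry over, and a step measured on one core cannot simply be transferred to the other as a fixed amount: the same change on two cores in this assay, a 9.9-fold lower number (1.00 log units; beyond the scatter) from compound 1 to compound 2 and a 2.3-fold lower number (0.35 log units; beyond the scatter) from compound 3 to compound 4, 4.4-fold (0.64 log units) apart, beyond the scatter of two such steps

These two pairs show the same direction on two cores only; they do not establish a rule for other cores, and they do not show which feature of the cores goes with the difference in step size.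

Still open, going by these compounds, is how other groups on the same aromatic carbon of the five-membered ring, such as ethyl or chlorine, would compare with methyl and hydrogen on each core. Also open, on these data alone, is whether the step would keep its direction on a further core, for example one with a longer chain in place of the chain in compound 3.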